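Ester and aryl replacement on the shared core

This account rests on a few compounds, and the source may have more. Where it says the series, first, only, none or still open, it means among the compounds named here.

Compound 1 `CC1=C(C(=O)OC2CCCCC2)C(c2cccc(Br)c2)C2=C(CC(C)(C)CC2=O)N1` and compound 2 `CC1=C(C(=O)OCc2ccc(C(C)(C)C)cc2)C(c2cccc(Br)c2)C2=C(CC(C)(C)CC2=O)N1` share the core; in an assay on HEK293 cells for inhibition of neurogenic locus notch homolog protein 1 (Homo sapiens), read by a luciferase reporter and resazurin assay, with a stated time of 16 h (on this read-out lower numbers stand for stronger inhibition and higher numbers for weaker inhibition), compound 1 gives 4150 nM and compound 2 gives 4270 nM. Among the compounds with values here, the only measured step, a 1.0-fold higher number from compound 1 to compound 2 (0.01 log units; within the scatter), swaps 4-(tert-butyl)benzyl in place of cyclohexyl on an oxygen next to a carbonyl group. Compound 3 `CC1=C(C(=O)OCC2CCN(C(=O)OC(C)(C)C)CC2)C(c2cccc([N+](=O)[O-])c2)C2=C(CC(C)(C)CC2=O)N1` yields no number but a limit of the assay, > 10000 nM, which is the limit of > 10000 nM in this assay, at which 1 of the 3 values shown sits. Compound 4 `CC1=C(C(=O)OCC2CCN(C(=O)OC(C)(C)C)CC2)C(c2ccc(Br)cc2F)C2=C(CC(C)(C)CC2=O)N1` carries 4-bromo-2-fluorophenyl in place of 3-nitrophenyl on a saturated ring carbon, 4-bromo-2-fluorophenyl in place of 3-nitrophenyl on a saturated ring carbon. Within the data shown here, no measured step touches this group, and the single measured step lies within the scatter. A step of an at least 1.1-fold lower number from compound 3 to compound 4 (0.04 log units; that floor lies within the scatter) is therefore expected, none beyond the scatter. Compound 4 is estimated at 9000 nM, between 3000 nM and 30000 nM.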

Compound 4, half-maximal inhibitory concentration: > 10000 nM
Compound 4: a limit, no number (the forecaster's own chance of this, stated with the estimate: 45%); at least 1.1-fold (0.04 log units) between middle value and limit.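

Compound 3 and compound 4 both stand at a limit of the assay, not a number, so no step between them can be read: the limit of > 10000 nM in this assay, at which 2 of the 4 values shown sit.

The compounds shown leave open whether 4-bromo-2-fluorophenyl in place of 3-nitrophenyl changes inhibition in this assay at all, and in which direction.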